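Aryl swap at the shared core: compound 2 to compound 3

The source may report more compounds than this note shows. Statements on the series, on what has been measured and on what is new or still open speak of the compounds shown alone.

Measured so far:
compound 1, `Cc1nc2c3ccccc3ccc2c2nc3c(ccc4ccccc43)c(-c3nccnc3N)c12`, 81.7 ug/mL
compound 2, `Cc1nc2c3ccccc3ccc2c2nc3c(ccc4ccccc43)c(-c3cccc4ccccc34)c12`, 111 ug/mL

For the measured compounds named here, in a functional assay, read by spectrophotometry, with a stated time of 30 min (a lower number here means a stronger inhibitor, a higher number a weaker inhibitor), compound 2 gives the highest of the two numbers so far, and its nearest neighbour is compound 1; the two stand within the scatter of each other, so no order between them is claimed.

The next compound, compound 3, `Cc1nc2c3ccccc3ccc2c2nc3c(ccc4ccccc43)c(-c3ccccc3Cl)c12`, differs from compound 2 in one place: 2-chlorophenyl in place of naphthalen-1-yl on an aromatic carbon. The aryl group enters on an aromatic carbon of a six-membered aromatic ring with one nitrogen, part of a fused or bridged system of six rings, opposite the ring nitrogen.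

Going by the values given here, only one measured step touches this position: a 1.4-fold higher number from compound 1 to compound 2 (0.13 log units; within the scatter). That step exchanged a ring with donors and acceptors for a ring without any, and the number moved within the scatter. The step now in hand exchanges one ring of carbon only for another, smaller ring of carbon only bearing chlorine; nothing measured here speaks for a move beyond the scatter in this assay.

Compound 3 is therefore expected near compound 2, with a step of a 1.1-fold lower number from compound 2 to compound 3 (0.05 log units; within the scatter), and an estimate of 100 ug/mL, range 50 ug/mL to 200 ug/mL.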

Compound 3, half-maximal inhibitory concentration: 118 ug/mL
Compound 3: the middle estimate sits 1.2-fold (0.07 log units) below what was measured; low and high end bracket the measured number.
By their numbers in this assay, from the lowest: compounds 1, 2 and 3 (each within the scatter of the next).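

In this assay, the exchange of naphthalen-1-yl for 2-chlorophenyl gives a 1.1-fold higher number from compound 2 to compound 3 (0.03 log units; within the scatter), so a group with one six-membered aromatic ring of carbon only and a chlorine reads the same, within the scatter, as a group with two such rings. The exchange of 3-aminopyrazin-2-yl for 2-chlorophenyl gives a 1.4-fold higher number from compound 1 to compound 3 (0.16 log units; within the scatter), which means that all three aryl groups on this aromatic carbon, opposite the ring nitrogen, now stand within the scatter of one another, and none of the three compounds goes against this; the position has so far tolerated a change in ring count and the entry of chlorine without a step that can be told from the scatter. No measurement at hand explains why these groups read alike.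

Still open, on these data alone, is whether the chlorine of compound 3 contributes anything on its own, which a plain phenyl would test, and whether the flat reading holds for groups of another kind on this carbon, such as a carboxylic acid, an aliphatic amine or a longer alkyl chain. Also open, as far as these compounds go, is how the number responds to changes elsewhere on the shared core, for instance at its methyl group.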